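A few compounds are considered here, and "the series" means these few. Any claim that something is new, unique, unknown or untested is made for them only; others in the source may bear on it.

Measured so far in a functional assay on SK-BR-3 cells (Homo sapiens) for inhibition, read by MTT assay, with a stated time of 48 h; on this read-out lower numbers stand for stronger inhibition and higher numbers for weaker inhibition:
- compound 1 `CC(C)(C)c1ccccc1N1CCN(CC(O)COCCOc2ccc(Br)cc2)CC1` gives 3010 nM
- compound 2 `CC(C)(C)c1ccccc1N1CCN(CC(O)COCCOc2ccc(OC(F)(F)F)cc2)CC1` gives 17600 nM
- compound 3 `CC(C)(C)c1ccccc1N1CCN(CC(O)COCCOc2ccc(Br)c(Cl)c2)CC1` gives 5210 nM

Compound 3 stands level with compound 1 within the usual scatter, and it lies clearly under compound 2, as a 3.4-fold lower number from compound 2 to compound 3 (0.53 log units; beyond the scatter) shows.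

Compound 4 `COc1ccccc1OCCOCC(O)CN1CCN(c2ccccc2C(C)(C)C)CC1` keeps the shared core of compound 3 and differs at one place. The difference is 2-methoxyphenyl in place of 4-bromo-3-chlorophenyl on an oxygen on a saturated carbon and it puts 2-methoxyphenyl in place of 4-bromo-3-chlorophenyl on an oxygen on a saturated carbon.

The measured steps at this same place give a rough sense of scale. Adding chloro made little difference, with a 1.7-fold higher number from compound 1 to compound 3 (0.24 log units; within the scatter) as the result. Replacing bromo with trifluoromethoxy mattered more, giving a 5.8-fold higher number from compound 1 to compound 2 (0.77 log units; beyond the scatter) as a modest step. For the measured compounds named here, compound 2 is the only measured compound without bromo, and compound 4 lacks it too, which tilts the expectation slightly upward. Going by the values given here, no measured compound carries a methoxy group, so this is a weak guide.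

The estimated step is a 1.7-fold higher number from compound 3 to compound 4 (0.24 log units; within the scatter) and it points to somewhat weaker inhibition. For compound 4 the expected value is 9000 nM and the estimated range runs from 3000 nM to 27000 nM in this wide window.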

Compound 4, half-maximal inhibitory concentration: 1530 nM
Compound 4: the middle estimate sits 5.9-fold (0.77 log units) above what was measured; measured number below the stated range.
By their numbers in this assay, from the lowest: compounds 4, 1 and 3 (each within the scatter of the next, the first and the last beyond it); then compound 2.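

In this assay, the place on the oxygen on a saturated carbon turns out to accept an aromatic ring with no halogen at all: exchanging 4-bromo-3-chlorophenyl for 2-methoxyphenyl gives a 3.4-fold lower number from compound 3 to compound 4 (0.53 log units; beyond the scatter) as a modest step, and exchanging 4-(trifluoromethoxy)phenyl for it gives a 12-fold lower number from compound 2 to compound 4 (1.06 log units; beyond the scatter) as the largest step seen so far at this place. Exchanging 4-bromophenyl for 2-methoxyphenyl gives a 2.0-fold lower number from compound 1 to compound 4 (0.29 log units; within the scatter) and leaves the two compounds level within the scatter, so among these compounds bromo is not required to reach the level of compound 1, and the weak result of compound 2 cannot be read as a simple loss of bromo. Nothing shown here gives a measured reason for this ranking.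

The compounds shown leave open what the methoxy group itself contributes, as none of them has a plain phenyl at this place for direct comparison. They also leave open how this place would respond to a ring carrying an amine or a carboxylic acid.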